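The source may report more compounds than this note shows. Statements on the series, on what has been measured and on what is new or still open speak of the compounds shown alone.

Working notes on the step from compound 2 to compound 4.

In an ADME assay on MCF-10A cells (Homo sapiens) for cytotoxicity, read by MTT assay, with a stated time of 5 days (on this read-out lower numbers stand for stronger inhibition and higher numbers for weaker inhibition), compound 2 `Nc1n[nH]c(=O)c2ncn([C@H]3C[C@H](O)[C@@H](CO)O3)c12` gives > 100000 nM, which is a limit of the assay and not a number. Compound 1 `Nc1n[nH]c(=O)c2c1ncn2[C@H]1C[C@H](O)[C@@H](CO)O1` gives > 100000 nM in this assay, again a limit only. The series thus sits largely at one ceiling, (the limit of > 100000 nM in this assay, at which 2 of the 3 values shown sit). Among the compounds with values here, compound 3 `Nc1n[nH]c(=O)c2c1ncn2[C@@H]1O[C@H](CO)[C@@H](O)[C@H]1O` gives 82500 nM in this assay, the one true number so far.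

The change under study leads to compound 4 `Nc1n[nH]c(=O)c2ncn([C@@H]3O[C@H](CO)[C@@H](O)[C@H]3O)c12` and is hydroxy in place of hydrogen on a saturated ring carbon. One measured step shows the same exchange on the other member of the pair of cores, an at least 1.2-fold lower number from compound 1 to compound 3 (0.08 log units; that floor lies within the scatter). From the compounds shown here alone, that figure is only a floor, and it lies within the scatter, so the true size of the step remains open. With this single step as the guide, no step beyond the scatter is expected in this assay, with any shift more likely toward lower numbers. A report of only a limit is about as likely as a number. The estimated step is a number no higher from compound 2 to compound 4 (the limit leaves the size open). For compound 4 the expected value is 100000 nM, with an estimated range of 50000 nM to 200000 nM.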

Compound 4, half-maximal inhibitory concentration: 82500 nM
For compound 4 the middle estimate is 1.2-fold (0.08 log units) above the measured one; low and high end bracket the measured number.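

In this assay the second core shows an at least 1.2-fold lower number from compound 2 to compound 4 (0.08 log units; that floor lies within the scatter) for hydroxy in place of hydrogen on the saturated ring carbon, so the exchange now has a reading on both cores, though only as a floor that lies within the scatter. Compound 4 reports a true number where compound 2 reports only a limit, which gives the exchange at this position the same form of result on each core, and the two readings can now be set side by side: the same change on two cores in this assay, an at least 1.2-fold lower number (0.08 log units; that floor lies within the scatter) from compound 1 to compound 3 and an at least 1.2-fold lower number (0.08 log units; that floor lies within the scatter) from compound 2 to compound 4; the limit leaves it open whether they differ. The hydroxy compounds on both cores thus stand off the ceiling, while the two compounds with hydrogen at this position remain on it: the limit of > 100000 nM in this assay, at which 2 of the 4 values shown sit.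

From the compounds shown here alone, the true size of the step stays open on both cores, as does whether it differs between them, since neither compound 1 nor compound 2 has a number to measure from. Also open, going by these compounds, is how other groups at this ring carbon would read in this assay, for instance an amine, a methoxy group or a fluorine atom, and whether any of them would give a step beyond the scatter.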